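Chloro in place of methoxy on the selenocyanate carbamate

A few compounds are considered here, and "the series" means these few. Any claim that something is new, unique, unknown or untested is made for them only; others in the source may bear on it.

The set comprises compound 1 `COc1ccc(OC(=O)Nc2ccc([Se]C#N)cc2)cc1`, compound 2 `O=C(Nc1ccc([Se][Se]c2ccc(NC(=O)Oc3ccccc3)cc2)cc1)Oc1ccccc1` and compound 3 `O=C(Nc1ccc([Se][Se]c2ccc(NC(=O)OCc3ccc([N+](=O)[O-])cc3)cc2)cc1)OCc1ccc([N+](=O)[O-])cc1`. In a functional assay on CCRF-CEM cells (Homo sapiens) for cytotoxicity, read by MTT assay, with a stated time of 72 h (a higher number here means a weaker inhibitor of growth, a lower number a stronger inhibitor of growth), compound 1 gives 41500 nM. In this assay compound 2 gives 48100 nM, and compound 3 gives 36500 nM. Compound 1 stands second highest of the three numbers; its gaps to compound 3 and to compound 2 both lie within the scatter, so no order among the three is claimed.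

Compound 4 `N#C[Se]c1ccc(NC(=O)Oc2ccc(Cl)cc2)cc1` is not yet measured. It differs from compound 1 by chloro in place of methoxy on an aromatic carbon. Going by the values given here, no measured pair in the set shows this exchange, so nothing in the data sets its size. The expected step is a 1.0-fold lower number from compound 1 to compound 4 (0.02 log units; within the scatter), which is none beyond the scatter. Compound 4 is estimated at 40000 nM, with a range of 18000 nM to 85000 nM.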

Compound 4, concentration for total growth inhibition: 45100 nM
Compound 4: middle estimate off by 1.1-fold (0.05 log units), on the low side, and the stated range covers the measured number.
By their numbers in this assay, from the lowest: compounds 3, 1, 4 and 2 (each within the scatter of the next).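

In this assay, going by these compounds alone, chloro in place of methoxy on this aromatic carbon, para to a large group, gives the first direct pair in the set (a 1.1-fold higher number from compound 1 to compound 4 (0.04 log units; within the scatter)). At this position, the exchange therefore leaves the number within the scatter, and the methoxy group is not needed to keep the growth inhibition seen with compound 1. Nothing on hand bears on a cause for this result. Going by these compounds, whether an amine or a carboxylic acid on this carbon would move the number beyond the scatter stays open. The same holds for a longer chain in place of methoxy.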